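The compounds below may be only part of what the source reports. "The series", "measured", "known", "first", "only" and "open" are said of these compounds alone.

Working notes on the series. In an ADME assay on GES1 cells (Homo sapiens) for inhibition, read by MTT assay, with a stated time of 72 h (a higher number here means a weaker inhibitor, a lower number a stronger inhibitor), compound 1 `Cc1cc(Nc2ccn(Cc3cccc4ccccc34)n2)n2nc(SCc3ccc(Br)cc3)nc2n1` gives 30000 nM. Compound 3 `Cc1cc(Nc2cc(-c3ccccc3)[nH]n2)n2nc(SCC(=O)c3ccccc3)nc2n1` gives 33300 nM, which lies within the scatter of the value for compound 1, so no order can be read between the two. Compound 2 `CCCCCc1c(C)nc2nc(SCc3ccc(Cl)cc3)nn2c1Nc1cc(-c2ccccc2)[nH]n1` is reported only as a limit, > 50000 nM.

The next structure is compound 4 `C=CCSc1nc2nc(C)cc(Nc3cc(-c4ccccc4)[nH]n3)n2n1`. Relative to compound 3, it has vinyl in place of benzoyl on a saturated chain carbon bound to a sulfur, which reads one bond further out as benzoylmethyl to allyl: vinyl in place of benzoyl on a saturated chain carbon bound to a sulfur. Among the measured compounds shown here, no measured pair differs in one place only, so this change has no direct precedent.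

Compound 1 at 30000 nM and compound 3 at 33300 nM differ in more than one place, yet their values stay within the scatter. On that basis, no shift beyond the scatter is expected in this assay, and any small drift is as likely to go in one direction as the other. The expected step of a 1.1-fold higher number from compound 3 to compound 4 (0.02 log units; within the scatter) is therefore small. A result reported only as a limit remains possible for this compound. The estimated value for compound 4 is 35000 nM, with an expected range from 17000 nM to 50000 nM.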

Compound 4, half-maximal inhibitory concentration: > 50000 nM
Compound 4 gave a limit, no number; the forecaster's own chance of this, stated with the estimate: 30%; middle value at least 1.4-fold (0.15 log units) from the limit.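

In this assay, among the compounds shown here, vinyl in place of benzoyl on a saturated chain carbon bound to a sulfur gives the first step between compounds that differ in one place only: an at least 1.5-fold higher number from compound 3 to compound 4 (0.17 log units; that floor lies within the scatter). Compound 4 is reported as a limit of the assay, not as a number: > 50000 nM. The change removes the six-membered aromatic ring of the benzoyl group without lowering the number at this place, but the step is only a floor and gives no true size, because the reading for compound 4 stops at the assay limit: the limit of > 50000 nM in this assay, at which 2 of the 4 values shown sit.

From the compounds shown here alone, how far the number really rises from benzoyl to vinyl stays open, and with a floor that lies within the scatter, the step does not yet establish a real difference between the two groups. Also open, going by these compounds, is whether an amine, a carboxylic acid or a longer alkyl chain on this saturated chain carbon would give a measurable number or another limit.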